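The source may hold more compounds than are shown below. What is called first, only, known or untested is meant among the compounds shown, and "the series" means these compounds.

In a functional assay on the whole organism for antagonist activity, with Mus musculus as the target (on this read-out lower numbers stand for an effect already at smaller amounts and higher numbers for an effect only at larger amounts of compound), compound 1 `CCC(=O)N(c1ccc(OC)cc1)C1CCCCC1N(C)C` gives > 50 mg/kg, which is a limit of the assay and not a number. Compound 2 `CCC(=O)N(c1cccc(C)c1)C1CCCC1N(C)C`, which differs from it in more than one place and also carries a methyl on its aromatic ring, gives 1 mg/kg; 1 mg/kg (2 entries). Compound 3 `CCC(=O)N(c1ccc(C)cc1)C1CCCCC1N(C)C` keeps the core of compound 1, with methyl in place of methoxy on an aromatic carbon, para to a large group (methyl in place of methoxy on an aromatic carbon). On the evidence of compound 2 at 1 mg/kg; 1 mg/kg (2 entries), the expected at least 3.3-fold lower number from compound 1 to compound 3 (0.52 log units; beyond the scatter) in this assay is a moderate one, towards smaller amounts. For compound 3 the estimated value is 15 mg/kg, with an expected range of 4 mg/kg to 50 mg/kg.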

Compound 3, dose for half-maximal effect: > 50 mg/kg
Compound 3 was reported as a limit; the forecaster's own chance of this, stated with the estimate: 35%; middle value at least 3.3-fold (0.52 log units) away from the limit.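

No step can be read from compound 1 to compound 3, as both results are limits of the assay and not numbers: the limit of > 50 mg/kg in this assay, at which 2 of the 3 values shown sit. The compounds shown leave open whether methyl in place of methoxy changes the dose at all in this assay.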